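Trifluoromethylphenyl urea in place of the chlorophenyl semicarbazide

A few compounds are considered here, and "the series" means these few. Any claim that something is new, unique, unknown or untested is made for them only; others in the source may bear on it.

Compound 1 `COc1cc(NC(C)CCCNC(=O)Nc2ccc(O)cc2)c2ncccc2c1` — 30000 nM
Compound 2 `COc1cc(NC(C)CCCNC(=O)NNC(=O)Nc2ccc(F)cc2)c2ncccc2c1` — > 100000 nM, a limit of the assay
Compound 3 `COc1cc(NC(C)CCCNC(=O)NNC(=O)Nc2ccc(Cl)cc2)c2ncccc2c1` — 48000 nM

In a functional assay on SW-620 cells (Homo sapiens) for inhibition, read by MTT assay, with a stated time of 72 h (a lower number here means a stronger inhibitor, a higher number a weaker inhibitor), compound 3 gives the highest of the two numbers; its nearest neighbour is compound 1, which shows a 1.6-fold higher number from compound 1 to compound 3 (0.20 log units; within the scatter). Compound 2 reports only a limit, (the limit of > 100000 nM in this assay, at which 1 of the 3 values shown sits). Between the two halogen analogues there is an at least 2.0-fold lower number from compound 2 to compound 3 (0.31 log units; beyond the scatter).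

Compound 4 `COc1cc(NC(C)CCCNC(=O)Nc2cccc(C(F)(F)F)c2)c2ncccc2c1` has not yet been measured. It differs from compound 3 in one place: 3-(trifluoromethyl)phenyl in place of ((4-chlorophenyl)carbamoyl)amino on an amide-type nitrogen.

Going by the values given here, no measured step carries this exact change. The nearest comparison is compound 1, which also carries an aryl group directly on that amide-type nitrogen and gives 30000 nM; its step to compound 3 stayed within the scatter. The halogen step from compound 2 to compound 3 was beyond the scatter but concerns a different part of the molecule. Compound 4 is therefore expected to land near compound 1 and compound 3, with no step beyond the scatter, as an estimated 25000 nM within 8000 nM to 80000 nM. This estimate corresponds to an expected 1.9-fold lower number from compound 3 to compound 4 (0.28 log units; within the scatter).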

Compound 4, half-maximal inhibitory concentration: 22000 nM
Compound 4: middle estimate off by 1.1-fold (0.06 log units), on the high side; the range from low to high includes it.
By their numbers in this assay, from the lowest: compounds 4, 1 and 3 (each within the scatter of the next, the first and the last beyond it). At a limit, above all of these: compound 2.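

In this assay, 3-(trifluoromethyl)phenyl in place of ((4-chlorophenyl)carbamoyl)amino on the amide-type nitrogen gives a 2.2-fold lower number from compound 3 to compound 4 (0.34 log units; beyond the scatter), whereas compound 1, which also has an aryl group directly on that nitrogen, stayed within the scatter of compound 3. Against the fluoro analogue, the same kind of change gives an at least 4.5-fold lower number from compound 2 to compound 4 (0.65 log units; beyond the scatter), a step read from a limit of the assay: the limit of > 100000 nM in this assay, at which 1 of the 4 values shown sits. The two aryl groups set directly on the nitrogen do not separate, with a 1.4-fold lower number from compound 1 to compound 4 (0.13 log units; within the scatter), so 4-hydroxyphenyl and 3-(trifluoromethyl)phenyl cannot be told apart here.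

Still open, going by these compounds, is how a 4-chlorophenyl group directly on that nitrogen would compare, which would part the effect of the aryl group from that of the longer carbamoylamino link. Also open, on these data alone, is whether a benzyl or pyridyl group there would give numbers like these.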